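The source may hold more compounds than are shown below. What is called first, only, known or untested is meant among the compounds shown, and "the series" means these compounds.

Compound 1 `O=c1c(SC(=S)N2CCCCC2)coc2ccccc12`: 17400 nM
Compound 2 `O=c1cc(CSC(=S)N2CCCC2)oc2cc(Cl)ccc12`: > 25000 nM, a limit of the assay
Compound 3 `O=c1cc(CSC(=S)N2CCOCC2)oc2ccccc12`: 22200 nM

In a functional assay on MDA-MB-435S cells (Homo sapiens) for antiproliferative activity, read by MTT assay, with a stated time of 72 h (on this read-out lower numbers stand for stronger inhibition and higher numbers for weaker inhibition), compound 1 gives 17400 nM, the lower of the two numbers shown, though compound 3 with 22200 nM sits within the scatter of it, so no order is claimed between them. Compound 2 reports only a limit, > 25000 nM, as noted in the limit of > 25000 nM in this assay, at which 1 of the 3 values shown sits. Compound 4 `O=c1c(SC(=S)N2CCCC2)coc2ccccc12` remains to be measured; it differs from compound 1 by pyrrolidin-1-yl in place of piperidin-1-yl on a thiocarbonyl carbon. For the measured compounds named here, no measured pair isolates this change, so for compound 4 in this assay no step beyond the scatter is expected, if anything a slight drift toward weaker inhibition. The estimate for compound 4 is 22000 nM, with a range from 9000 nM to 50000 nM. The expected step is a 1.3-fold higher number from compound 1 to compound 4 (0.10 log units; within the scatter).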

Compound 4, half-maximal inhibitory concentration: 1900 nM
Compound 4: middle estimate off by 12-fold (1.06 log units), on the high side, outside the stated range (below it).
By their numbers in this assay, from the lowest: compound 4; then compounds 1 and 3 (each within the scatter of the next). At a limit, above all of these: compound 2.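

In this assay pyrrolidin-1-yl in place of piperidin-1-yl on a thiocarbonyl carbon gives a 9.2-fold lower number from compound 1 to compound 4 (0.96 log units; beyond the scatter) with the shared core unchanged, so activity in this series responds to this ring alone. This is the first pair shown that isolates a single change, and it shows that the ring at this place is not a silent choice. No measured property shown bears on this step.

From the compounds shown here alone, whether azetidin-1-yl or an open-chain dimethylamino group would continue this step remains open. Also open, going by these compounds, is whether the same ring change gives a similar step on cores carrying a chloro substituent.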